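Replacing a methylpyrazine amide with a pyrimidine amide

The source may hold more compounds than are shown below. What is called first, only, known or untested is meant among the compounds shown, and "the series" means these compounds.

The compounds here share one core, seen in compound 1 `O=C(Nc1cc(F)cc2cccnc12)c1ncccn1`, with an aromatic amide attached to it. In a functional assay on PANC-1 cells (Homo sapiens) for inhibition, read by MTT assay, with a stated time of 72 h (on this read-out lower numbers stand for stronger inhibition and higher numbers for weaker inhibition), compound 1 gives 5300 nM. Compound 2 `NCCOc1cc(NC(=O)c2cnccn2)c2ncccc2c1` carries a 2-aminoethoxy chain on the core and a pyrazine amide. In this assay compound 2 reaches only > 10000 nM, which is a limit of the measurement and not a number. Compound 3 `Cc1cnc(C(=O)Nc2cc(OCCN)cc3cccnc23)cn1` adds a methyl group to that pyrazine. For compound 3 this assay again records only > 10000 nM, a limit. The step that the two limits leave unreadable from compound 2 to compound 3 therefore cannot be sized, because the limit of > 10000 nM in this assay, at which 2 of the 3 values shown sit, hides whatever change the methyl brought. So compound 3 stands at the limit, with no number of its own. Compound 4 `NCCOc1cc(NC(=O)c2ncccn2)c2ncccc2c1` differs from compound 3 by pyrimidin-2-yl in place of 5-methylpyrazin-2-yl on a carbonyl carbon. Among the compounds with values here, no measured step covers this swap directly: compound 1, which carries the same pyrimidine amide but lacks the aminoethoxy chain, gives a number, while both compounds with that chain sit at the limit. From compound 3 to compound 4 the expected step is a step that the limit leaves unreadable from compound 3 to compound 4, within the scatter. Compound 4 is therefore estimated at 12000 nM, in the range 4000 nM to 40000 nM, and most likely reported once more only as a limit.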

Compound 4, half-maximal inhibitory concentration: > 10000 nM
Compound 4 was reported as a limit; the forecaster's own chance of this, stated with the estimate: 65%; the middle value is on the limit's open side.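

Compound 4 is recorded only as a limit, > 10000 nM, and not as a number. Within the data shown here, it does supply the first pair that isolates the chain: 2-aminoethoxy in place of fluoro on an aromatic carbon gives, in this assay, an at least 1.8-fold higher number from compound 1 to compound 4 (0.27 log units; that floor lies within the scatter), so this pair points the same way as the limits but does not yet establish a real loss of inhibition. With the chain in place, the pyrazin-2-yl, 5-methylpyrazin-2-yl and pyrimidin-2-yl amides cannot be told apart, and the steps among them cannot be read because all three compounds sit at one ceiling: the limit of > 10000 nM in this assay, at which 3 of the 4 values shown sit.

On these data alone, what stays open is whether a methoxy group or a longer chain such as 3-aminopropoxy on that aromatic carbon would bring a compound back to a measurable number. Also open is whether the choice of ring on the carbonyl carbon matters at all, since among the compounds shown only compound 1, with fluoro in that place, gives a number that can serve as a reference.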